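This account rests on a few compounds, and the source may have more. Where it says the series, first, only, none or still open, it means among the compounds named here.

Measured so far in a functional assay on A-375 cells (Homo sapiens) for cytotoxicity, read by MTT assay, with a stated time of 48 h; a lower number here means a stronger inhibitor, a higher number a weaker inhibitor:
compound 1 `CC1(C)[C@H](C(=O)OC(c2ccccc2)c2ccccc2)N2C(=O)/C(=C/C(=O)c3ccc([N+](=O)[O-])cc3)[C@H]2[S+]1[O-]`: 48200 nM
compound 2 `CC1(C)S[C@@H]2/C(=C\C(=O)c3ccc([N+](=O)[O-])cc3)C(=O)N2[C@H]1C(=O)OC(c1ccccc1)c1ccccc1`: 50300 nM
compound 3 `CC1(C)S[C@@H]2/C(=C\C(=O)c3ccccc3)C(=O)N2[C@H]1C(=O)OC(c1ccccc1)c1ccccc1`: 22800 nM

Compound 4 `CC1(C)[C@H](C(=O)OC(c2ccccc2)c2ccccc2)N2C(=O)/C(=C/C(=O)c3ccccc3)[C@H]2[S+]1[O-]` has not been measured in this assay. Compound 1 and compound 2 share the nitro-bearing side chain but differ in their cores; that difference between the two cores is not broken down here, and the values of compound 1 and compound 2 in this assay lie within the scatter of each other. From compound 2 to compound 3 the change hydrogen in place of nitro on an aromatic carbon gave a 2.2-fold lower number from compound 2 to compound 3 (0.34 log units; beyond the scatter). From compound 1 to compound 4 the change hydrogen in place of nitro on an aromatic carbon is the same, made at the same place on the same aromatic ring. It is therefore expected that compound 4 will follow the same step as compound 3, resting on the step from compound 2 to compound 3 a 2.2-fold lower number from compound 2 to compound 3 (0.34 log units; beyond the scatter), giving an expected 2.2-fold lower number from compound 1 to compound 4 (0.34 log units; beyond the scatter). Compound 4 is estimated at 22000 nM in this assay, expected between 11000 nM and 45000 nM.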

Compound 4, half-maximal inhibitory concentration: 4500 nM
The estimate for compound 4 lay 4.9-fold (0.69 log units) above the measured number, outside the stated range (below it).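

In this assay, hydrogen in place of nitro on the aromatic ring gave an 11-fold lower number from compound 1 to compound 4 (1.03 log units; beyond the scatter), so the direction of the step carried over from one core to the other. Its size did not carry over, and the two steps stand apart: the same change on two cores in this assay, a 2.2-fold lower number (0.34 log units; beyond the scatter) from compound 2 to compound 3 and an 11-fold lower number (1.03 log units; beyond the scatter) from compound 1 to compound 4, 4.9-fold (0.69 log units) apart, beyond the scatter of two such steps

With a single pair on each core, this shows that a step measured on one core cannot be transferred at full size to the other, but it does not show why the steps differ or whether the gap holds for other groups.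

Going by these compounds, only nitro and hydrogen appear at this place on the ring, so it remains open whether an amine or a methoxy group would show the same gap between the cores. The ester is also the same in all four compounds, leaving open how a free carboxylic acid there would behave.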